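A few compounds are considered here, and "the series" means these few. Any claim that something is new, unique, unknown or untested is made for them only; others in the source may bear on it.

Working notes on a short chalcone-type series tested in an assay for inhibition of Amine oxidase [flavin-containing] B (Homo sapiens), read by spectrophotometry, using microsomes, with a stated time of 5 min, tested at 10 uM; a lower number here means less inhibition, a higher number more inhibition at the concentration tested (going by the name of the read-out).

Compound 1 `COc1cccc(/C=C/C(=O)c2cccc(C(F)(F)F)c2)c1OC` gives 63% in this assay. Compound 2 `COc1cccc(/C=C/C(=O)c2ccccc2C(F)(F)F)c1OC` gives 27%, and compound 3 `COc1cccc(/C=C/C(=O)c2ccc(SC)cc2)c1OC` gives 36%. On these three numbers compound 1 stands highest: compound 3 is its nearest neighbour, a number lower by a margin beyond the scatter, and compound 2 is furthest, lower by a wider margin, also beyond the scatter. Among the measured compounds shown here, no pair among the three measured compounds differs in only one place, so no single-point step is available within the measured set.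

Compound 4 `COc1cccc(/C=C/C(=O)c2cccc(OC(F)(F)F)c2)c1OC` has not yet been measured. It differs from compound 1 in one place: trifluoromethoxy in place of trifluoromethyl on an aromatic carbon.

With no measured step of this kind in the series, only a cautious expectation can be framed. For compound 4 the expected step from compound 1 is a number 8 percentage points lower from compound 1 to compound 4 (within the scatter), a change not expected to exceed the scatter in either direction. The estimate for compound 4 in this assay is 55%, with a range from 30% to 80%, resting on the value of compound 1 at 63%.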

Compound 4, a percentage reported as inhibition, at one concentration (the size of the read-out at that concentration, not a potency): 41%
Beside the measured number, compound 4's estimate is 14 percentage points above it; measured number inside the range.
By their numbers in this assay, from the lowest: compounds 2, 3 and 4 (each within the scatter of the next, the first and the last beyond it); then compound 1.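

Among the compounds shown here, this is the first single-place step, and it falls on an aromatic carbon of the six-membered aromatic ring, meta to a large group: in this assay, trifluoromethoxy in place of trifluoromethyl gives a number 22 percentage points lower from compound 1 to compound 4 (beyond the scatter) and so is not an interchangeable replacement at this place. The read-out therefore responds to this change, even though the entering group differs from the leaving one only by an added oxygen and a hydrogen-bond acceptor in the computed comparison. No measured property of either group accompanies the step, so the data offer no account of it.

Still open, as far as these compounds go, is how a nitrile, an amine or a carboxylic acid would read at this place. One step at one tested concentration also leaves open whether the same change would give a similar step elsewhere on the core, and it gives no potency.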